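Series notes: the step from compound 2 to compound 4

The source may hold more compounds than are shown below. What is called first, only, known or untested is meant among the compounds shown, and "the series" means these compounds.

Measured compounds:
compound 1 `CCCSc1nc(N[C@@H]2C[C@H]2c2ccc(F)c(F)c2)c2nnn([C@@H]3C[C@H](OC(C)=O)[C@@H](O)[C@H]3O)c2n1`, "not determined" (no result reported) in a functional assay on the whole organism (strain Sprague-Dawley) for inhibition, with Rattus norvegicus as the target, with a stated time of 0.5 h, at a dose of 5 mg/kg by the oral route; on this read-out lower numbers stand for less inhibition and higher numbers for more inhibition at the one dose given (going by the name of the read-out)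
compound 2 `CCCSc1nc(N[C@@H]2C[C@H]2c2ccc(F)c(F)c2)c2nnn([C@@H]3C[C@H](OCCOC(=O)OCC)[C@@H](O)[C@H]3O)c2n1`, 47.7%
compound 3 `CCCSc1nc(N[C@@H]2C[C@H]2c2ccc(F)c(F)c2)c2nnn([C@@H]3C[C@H](OC(=O)OCC)[C@@H](O)[C@H]3O)c2n1`, 42.6%

Going by the values given here, only two numbers exist in this assay. Compound 2 gives 47.7% and compound 3 gives 42.6%, and the step of a number 5.1 percentage points lower from compound 2 to compound 3 (within the scatter) lies within the scatter, so the two cannot be told apart. Compound 4 `CCCSc1nc(N[C@@H]2C[C@H]2c2ccc(F)c(F)c2)c2nnn([C@@H]3C[C@H](OCCOC(=O)C(C)(C)C)[C@@H](O)[C@H]3O)c2n1` differs from compound 2 by tert-butyl in place of ethoxy on a carbonyl carbon. Among the compounds with values here, the one measured step, a number 5.1 percentage points lower from compound 2 to compound 3 (within the scatter), also changed the group on an oxygen on a saturated carbon and left the read-out flat; no measured step covers the present exchange itself. In this assay compound 4 is therefore expected to give 45%, in the range 25% to 65%. The expected step of a number 2.7 percentage points lower from compound 2 to compound 4 (within the scatter) stays within the scatter.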

Compound 4, a percentage reported as inhibition, in the whole organism at one dose (the size of the read-out at that dose, not a potency): 46.1%
Compound 4: the middle estimate sits 1.1 percentage points below what was measured, and the stated range covers the measured number.
By their numbers in this assay, from the lowest: compounds 3, 4 and 2 (each within the scatter of the next).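

In this assay, tert-butyl in place of ethoxy on a carbonyl carbon gives a number 1.6 percentage points lower from compound 2 to compound 4 (within the scatter), so this exchange leaves the read-out flat at the one dose given. Likewise, 2-(((tert-butyl)carbonyl)oxy)ethyl in place of ethoxycarbonyl on an oxygen on a saturated carbon gives a number 3.5 percentage points higher from compound 3 to compound 4 (within the scatter), and compounds 2, 3 and 4 cannot be told apart. Nothing at hand bears on why the read-out stays flat. Still open, from the compounds shown here alone, is whether an amine or a carboxylic acid in place of tert-butyl on the carbonyl carbon would give a step beyond the scatter. Going by these compounds, a longer chain on that oxygen remains equally open.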